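The source may hold more compounds than are shown below. What is called first, only, known or untested is meant among the compounds shown, and "the series" means these compounds.

Measured in an ADME assay on L02 cells (Homo sapiens) for cytotoxicity, read by MTT assay, with a stated time of 48 h; on this read-out lower numbers stand for stronger inhibition and higher numbers for weaker inhibition:
Compound 1 `CCN(CC)CCNC(=O)c1ccc(C(CC)(CC)c2ccc(OCC(=O)C(C)(C)C)c(C)c2)n1CC`: 2500 nM
Compound 2 `CCn1c(C(=O)NCCCN(C)C)ccc1C(CC)(CC)c1ccc(OCC(=O)C(C)(C)C)c(C)c1`: 670 nM
Compound 3 `CCn1c(C(=O)NCCCN(C)C)ccc1C(CC)(CC)c1ccc(OCC(O)C(C)(C)C)c(C)c1`: 470 nM

Compound 3 stands level with compound 2, as a 1.4-fold lower number from compound 2 to compound 3 (0.15 log units; within the scatter) shows, and compound 1 carries the clearly higher number. Compound 4 `CCn1c(C(=O)N(CCC#N)CCC#N)ccc1C(CC)(CC)c1ccc(OCC(O)C(C)(C)C)c(C)c1` differs from compound 3 on a carbonyl carbon, where (3-(dimethylamino)propyl)amino leaves: a group of 9 heavy atoms (6 carbon, 3 nitrogen; no ring) in place of a group of 7 heavy atoms (5 carbon, 2 nitrogen; no ring), on a carbonyl carbon. For the measured compounds named here, the one measured step inside the leaving group is a 3.7-fold lower number from compound 1 to compound 2 (0.57 log units; beyond the scatter), which is modest. The step of a 1.4-fold lower number from compound 2 to compound 3 (0.15 log units; within the scatter) lies elsewhere and offers little guidance. Going by the values given here, no measured compound shows a change as large as this one, so the direction is uncertain. A modest rise is expected, and the estimated step is a 4.3-fold higher number from compound 3 to compound 4 (0.63 log units; beyond the scatter). The estimate for compound 4 is 2000 nM, with an expected range of 600 nM to 7000 nM.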

Compound 4, half-maximal inhibitory concentration: 1700 nM
Beside the measured number, compound 4's estimate is 1.2-fold (0.07 log units) above it, and the stated range covers the measured number.
By their numbers in this assay, from the lowest: compounds 3 and 2 (each within the scatter of the next); then compounds 4 and 1 (each within the scatter of the next).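

Replacing (3-(dimethylamino)propyl)amino on the carbonyl carbon gives a 3.6-fold higher number from compound 3 to compound 4 (0.56 log units; beyond the scatter) in this assay, so this position can also push the number upward, whereas the earlier step here, a 3.7-fold lower number from compound 1 to compound 2 (0.57 log units; beyond the scatter), ran downward. The entering group differs at once in size, in its triple bonds and in having 0 hydrogen-bond donors, so the step cannot be assigned to any one of these. No evidence is available to explain the rise. The compounds shown leave open which of these differences matters. A single 2-cyanoethyl chain on the amide nitrogen, retaining the amide hydrogen, would help separate them.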